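The source may report more compounds than this note shows. Statements on the series, on what has been measured and on what is new or still open speak of the compounds shown alone.

In a functional assay on NCI-H460 cells (Homo sapiens) for cytotoxicity, read by MTT assay, with a stated time of 72 h (on this read-out higher numbers stand for weaker inhibition and lower numbers for stronger inhibition), compound 1 (`Cc1ccc(/C=c2\[nH]c(=O)/c(=C/c3cccc(Oc4ccc(F)cc4)c3)[nH]c2=O)o1`) gives 30 nM and compound 2 (`COCc1ccc(/C=c2\[nH]c(=O)/c(=C/c3cccc(Oc4ccc(F)cc4)c3)[nH]c2=O)o1`) gives 14 nM, the lower of the two numbers. Compound 3 (`O=c1[nH]/c(=C\c2nc3ccccc3[nH]2)c(=O)[nH]/c1=C\c1cccc(Oc2ccc(F)cc2)c1`) differs from compound 2 as follows: 1H-benzimidazol-2-yl in place of 5-(methoxymethyl)furan-2-yl on a double-bonded chain carbon bound to an aromatic carbon. Among the measured compounds shown here, the only measured step, a 2.1-fold lower number from compound 1 to compound 2 (0.33 log units; beyond the scatter), is modest and leaves the furan ring in place, so it offers weak guidance for this exchange. For the measured compounds named here, no measured compound carries 1H-benzimidazol-2-yl. A modest move towards a higher number is expected, with low confidence in its direction: a 2.9-fold higher number from compound 2 to compound 3 (0.46 log units; beyond the scatter). For compound 3 the estimated value is 40 nM, with an expected range of 10 nM to 200 nM.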

Compound 3, half-maximal inhibitory concentration: > 1000 nM
Compound 3 was reported as a limit; the forecaster's own chance of this, stated with the estimate: 5%; at least 25-fold (1.39 log units) between middle value and limit.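

In this assay compound 3 is reported as a limit rather than a number: the limit of > 1000 nM in this assay, at which 1 of the 3 values shown sits.

Among the compounds shown here, replacing either furan with 1H-benzimidazol-2-yl on the double-bonded chain carbon is the first large change: an at least 71-fold higher number from compound 2 to compound 3 (1.85 log units; beyond the scatter), and an at least 33-fold higher number from compound 1 to compound 3 (1.52 log units; beyond the scatter). So this place, where 5-methylfuran-2-yl and 5-(methoxymethyl)furan-2-yl both give low numbers, does not accept every aromatic ring.

On these data alone, it remains open whether the loss follows the ring nitrogens or the six-membered carbon ring. Imidazol-2-yl, benzofuran-2-yl and 1-methylbenzimidazol-2-yl would separate these.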